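A Propylcarbonyl Group Enters Compound 3

The source may hold more compounds than are shown below. What is called first, only, known or untested is meant among the compounds shown, and "the series" means these compounds.

Compound 3 `OB1OCc2ccc(-n3cccc3)cc21` is one of three compounds tested in an ADME assay on L929 cells (Mus musculus) for cytotoxicity, read by resazurin assay, with a stated time of 72 h; on this read-out lower numbers stand for stronger inhibition and higher numbers for weaker inhibition. In this assay compound 3 gives only a limit, > 10 ug/mL. Compound 1 `OB1OCc2ccc(-n3cc(Sc4ccc(F)cc4)c4ccccc43)cc21` likewise gives a limit in this assay, > 10 ug/mL. Compound 2 `OB1OCc2ccc(-n3cc(Sc4ccc5ccccc5c4)c4ccccc43)cc21` also gives a limit in this assay, > 10 ug/mL. The step that the two limits leave unreadable from compound 1 to compound 2 therefore cannot be read, since the limit of > 10 ug/mL in this assay, at which 3 of the 3 values shown sit, is where every value sits. Compound 4 `CCCC(=O)c1ccn(-c2ccc3c(c2)B(O)OC3)c1` differs from compound 3 by propylcarbonyl in place of hydrogen on an aromatic carbon. For the measured compounds named here, no measured step bears on this change, and the single step between measured compounds, naphthalen-2-yl in place of 4-fluorophenyl on a sulfur, stays at the limit. Across these compounds no change moved the read-out away from the limit, so no step beyond the scatter is expected, a step that the limit leaves unreadable from compound 3 to compound 4. Compound 4 is estimated at 15 ug/mL, within 7 ug/mL to 40 ug/mL.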

Compound 4, half-maximal inhibitory concentration: > 10 ug/mL
Compound 4 gave a limit, no number (the forecaster's own chance of this, stated with the estimate: 75%); the middle value does not contradict the limit.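

Compound 4 gives only a limit in this assay, > 10 ug/mL. No step from compound 3 to compound 4 can therefore be read: the limit of > 10 ug/mL in this assay, at which 4 of the 4 values shown sit.

The compounds shown leave open whether propylcarbonyl in place of hydrogen on an aromatic carbon changes the read-out at all.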